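A few compounds are considered here, and "the series" means these few. Any claim that something is new, unique, unknown or untested is made for them only; others in the source may bear on it.

In an ADME assay on microsomes from liver (Rattus norvegicus) for metabolic stability, read by LC-MS, in the presence of a further agent that is not named here (a higher number here means faster removal of the compound, a lower number slower removal), compound 1 `Cc1ncc(C)n2nc(-c3ccc4nc(-c5ccccn5)[nH]c4c3)nc12` gives 11.1 mL.min-1.g-1. Compound 2 `Cc1ncc(C)n2nc(-c3ccn4cc(-c5ccccc5Br)nc4n3)nc12` gives 1.8 mL.min-1.g-1, so compound 1 holds the higher of the two numbers, by a gap beyond the usual scatter. These two molecules differ in more than one place, so their gap cannot be pinned on any single group.

Within the data shown here, compound 3 `Cc1ncc(C)n2nc(-c3ccc4nc(-c5ccccc5)[nH]c4c3)nc12` keeps the core of compound 1 and changes only one group: phenyl in place of pyridin-2-yl on an aromatic carbon. A ring of carbon only thus takes the place of a ring that holds a hetero atom, on a carbon between two ring nitrogen atoms.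

Among the measured compounds shown here, no pair of measured compounds shows what a swap like this does, so the expectation starts from compound 1 at 11.1 mL.min-1.g-1 and stays cautious. The expected change is small and upward, within the scatter: a 1.3-fold higher number from compound 1 to compound 3 (0.10 log units; within the scatter). In this assay, compound 3 is expected to give about 14 mL.min-1.g-1, with an estimated range from 7 mL.min-1.g-1 to 28 mL.min-1.g-1.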

Compound 3, intrinsic clearance in microsomes: 27.4 mL.min-1.g-1
Compound 3: the middle estimate sits 2.0-fold (0.29 log units) below what was measured; low and high end bracket the measured number.
By their numbers in this assay, from the lowest: compound 2; then compound 1; then compound 3.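

In this assay, among these compounds, this is the first comparison in which only one group changes, and phenyl in place of pyridin-2-yl on an aromatic carbon gives a 2.5-fold higher number from compound 1 to compound 3 (0.39 log units; beyond the scatter) and so lies beyond the usual scatter. At this carbon between two ring nitrogen atoms, the number therefore responds to the make-up of the ring: the ring of carbon only goes with a higher number than the ring with a hetero atom, although both have the same count of heavy atoms and neither carries a net charge. No measurement shown here explains why the number moves, so the step stands as an observation on this one pair.

On these data alone, whether other groups at this carbon, such as an amine, a carboxylic acid or a longer alkyl chain, would raise or lower the number remains open. Among the compounds shown here, with only one pair to go on, it is also unknown whether the same swap would give a similar step on a different core, such as that of compound 2.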